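Amide replacements on the shared core: nitro to methyl

The source may report more compounds than this note shows. Statements on the series, on what has been measured and on what is new or still open speak of the compounds shown alone.

In an assay for binding affinity to 5-hydroxytryptamine receptor 1F (Homo sapiens), read by radioligand binding (on this read-out lower numbers stand for stronger inhibition and higher numbers for weaker inhibition), the measured compounds give:
compound 1 `CCCCCCCC(=O)Nc1ccc2[nH]cc(C3CCN(C)CC3)c2n1` — 20 nM
compound 2 `Cc1cccc(C(=O)Nc2ccc3[nH]cc(C4CCN(C)CC4)c3n2)c1` — 5.8 nM
compound 3 `CN1CCC(c2c[nH]c3ccc(NC(=O)c4ccc([N+](=O)[O-])cc4)nc23)CC1` — 7.7 nM

Compound 3 stands second highest of these three numbers. Its nearest neighbour is compound 2, with a 1.3-fold higher number from compound 2 to compound 3 (0.12 log units; within the scatter), a difference within the scatter; the furthest is compound 1, with a 2.6-fold lower number from compound 1 to compound 3 (0.41 log units; beyond the scatter), beyond the scatter. Compound 4 `Cc1ccc(C(=O)Nc2ccc3[nH]cc(C4CCN(C)CC4)c3n2)cc1` differs from compound 3 by methyl in place of nitro on an aromatic carbon.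

Of the measured steps only the exchange of 3-methylphenyl for 4-nitrophenyl, a 1.3-fold higher number from compound 2 to compound 3 (0.12 log units; within the scatter), bears on this change, and it lies within the scatter. Among the compounds with values here, no step on this core compares a methyl with a nitro on the same position. The step is therefore expected to be a 1.3-fold lower number from compound 3 to compound 4 (0.11 log units; within the scatter), within the scatter. Compound 4 is estimated at 6 nM, range 2.5 nM to 15 nM.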

Compound 4, inhibition constant: 12 nM
Estimate against measurement, compound 4: 2.0-fold (0.30 log units) below; the measured number falls inside the stated range.
By their numbers in this assay, from the lowest: compounds 2, 3, 4 and 1 (each within the scatter of the next, the first and the last beyond it).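

On this aromatic carbon, methyl in place of nitro gives no resolved change in this assay (a 1.6-fold higher number from compound 3 to compound 4 (0.19 log units; within the scatter)). Moving the methyl does register, as 4-methylphenyl in place of 3-methylphenyl is a modest step (a 2.1-fold higher number from compound 2 to compound 4 (0.32 log units; beyond the scatter)), the first resolved difference between aryl amides. Unlike 3-methylphenyl and 4-nitrophenyl, 4-methylphenyl is not resolved from heptyl (a 1.7-fold lower number from compound 1 to compound 4 (0.22 log units; within the scatter)).

No evidence accompanies these steps that could account for them. Going by these compounds, whether an amine or a carboxylic acid on this aromatic carbon would move the number remains open.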